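Triazole nitrogen substituent and cytotoxicity in the series

A few compounds are considered here, and "the series" means these few. Any claim that something is new, unique, unknown or untested is made for them only; others in the source may bear on it.

Compound 1 `CC(C)CCn1nc(C(=O)N[C@H]2COc3ccccc3N(C)C2=S)nc1Cc1ccccc1`: in a toxicity assay on HT-29 cells (Homo sapiens) for cytotoxicity (on this read-out higher numbers stand for lower toxicity in this test and lower numbers for higher toxicity in this test), compound 1 gives > 100000 nM, a limit of the assay.
Compound 2 `COCCn1nc(C(=O)N[C@H]2COc3ccccc3N(C)C2=S)nc1Cc1ccccc1`: in this assay compound 2 gives > 100000 nM, a limit of the assay.
Compound 3 `CN1C(=S)[C@@H](NC(=O)c2nc(Cc3ccccc3)n(CCCO)n2)COc2ccccc21`: in this assay compound 3 gives > 100000 nM, a limit of the assay.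

Compound 2 therefore stands at the limit of the assay, as do both other measured compounds (the limit of > 100000 nM in this assay, at which 3 of the 3 values shown sit). The steps a step that the two limits leave unreadable from compound 1 to compound 2, a step that the two limits leave unreadable from compound 1 to compound 3 and a step that the two limits leave unreadable from compound 2 to compound 3 are all unreadable, so nothing quantitative is known about how the group on the aromatic nitrogen moves this assay.

Compound 4 `CN1C(=S)[C@@H](NC(=O)c2nc(Cc3ccccc3)n(-c3ncccn3)n2)COc2ccccc21` differs from compound 2 as follows: pyrimidin-2-yl in place of 2-methoxyethyl on an aromatic nitrogen. Going by the values given here, no measured step bears readably on this change. With every measured value at the limit, compound 4 is expected to remain at that limit in this assay, giving an estimated 100000 nM within 30000 nM to 300000 nM. The expected step is a number no higher from compound 2 to compound 4 (the limit leaves the size open), that is, none beyond the scatter.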

Compound 4, half-maximal cytotoxic concentration: > 100000 nM
Compound 4 was reported as a limit (the forecaster's own chance of this, stated with the estimate: 80%); the middle value sits exactly at the limit.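

In this assay the steps from compound 1, compound 2 and compound 3 to compound 4 cannot be read, since all four compounds sit at a limit: the limit of > 100000 nM in this assay, at which 4 of the 4 values shown sit.
On these data alone, whether any group on the aromatic nitrogen changes this read-out at all, and by how much, stays open.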